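Aryl Amide Variation in a Dopamine D(4) Agonist Series

A few compounds are considered here, and "the series" means these few. Any claim that something is new, unique, unknown or untested is made for them only; others in the source may bear on it.

Compound 1 `O=C(CN1CCC(c2cccc[n+]2[O-])CC1)Nc1ccc(F)cc1F`: 103 nM
Compound 2 `O=C(CN1CCC(c2cccc[n+]2[O-])CC1)Nc1cccc(F)c1`: 160 nM

In a functional assay on HEK293 cells for agonist activity at D(4) dopamine receptor (Homo sapiens), read by FLIPR (a lower number here means that less compound is needed, a higher number that more compound is needed for the effect), compound 1 gives 103 nM and compound 2 gives 160 nM. Among the measured compounds shown here, of these two numbers, compound 2 holds the higher, but the only measured step, a 1.6-fold higher number from compound 1 to compound 2 (0.19 log units; within the scatter), lies within the scatter, so the two are not told apart. Compound 3 `Cc1cccc(C)c1NC(=O)CN1CCC(c2cccc[n+]2[O-])CC1` differs from compound 2 by 2,6-dimethylphenyl in place of 3-fluorophenyl on an amide-type nitrogen. For the measured compounds named here, no measured step touches a 2,6-dimethylphenyl; the one step at hand swaps one fluorophenyl for another and is within the scatter, so it gives little guidance. The expected step is a 1.6-fold higher number from compound 2 to compound 3 (0.19 log units; within the scatter), a modest rise scarcely beyond the scatter. Compound 3 is therefore estimated at 250 nM, within 80 nM to 800 nM.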

Compound 3, half-maximal effective concentration: 346 nM
Compound 3: middle estimate off by 1.4-fold (0.14 log units), on the low side, and the stated range covers the measured number.
By their numbers in this assay, from the lowest: compounds 1 and 2 (each within the scatter of the next); then compound 3.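

On the amide-type nitrogen, the aryl group can shift the number beyond the scatter, which the two fluorophenyl compounds did not show. In this assay, 2,6-dimethylphenyl in place of 3-fluorophenyl gives a 2.2-fold higher number from compound 2 to compound 3 (0.33 log units; beyond the scatter), and in place of 2,4-difluorophenyl it gives a 3.4-fold higher number from compound 1 to compound 3 (0.53 log units; beyond the scatter). No evidence is at hand to explain these modest rises.

As far as these compounds go, the swap exchanges fluorine for methyl groups in one change, so the contribution of each remains open. Also open, from the compounds shown here alone, is how an unsubstituted phenyl or a 2,6-difluorophenyl on the same nitrogen would read.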